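Cyclopentylamine removal in an imidazo-fused purine series

The source may report more compounds than this note shows. Statements on the series, on what has been measured and on what is new or still open speak of the compounds shown alone.

Measured so far:
compound 1 `CCCn1c(-c2ccccc2)nc2c(NC3CCCC3)ncnc21` gives 749 nM
compound 2 `Cn1c(-c2ccccc2)nc2c(NC3CCCC3)ncnc21` gives 846 nM
compound 3 `CCn1c(-c2ccccc2)nc2c(NC3CCCC3)ncnc21` gives 354 nM

All numbers come from an assay on CHO cells for displacement of a labelled ligand from adenosine receptor A3 (Homo sapiens), read by scintillation counting, with a stated time of 3 h; on this read-out lower numbers stand for stronger inhibition and higher numbers for weaker inhibition. Compound 1 stands second highest of the three. Its nearest neighbour is compound 2: the step of a 1.1-fold higher number from compound 1 to compound 2 (0.05 log units; within the scatter) is within the scatter, so the two cannot be ordered. The step of a 2.1-fold lower number from compound 1 to compound 3 (0.33 log units; beyond the scatter) is beyond the scatter and modest, and the step of a 2.4-fold lower number from compound 2 to compound 3 (0.38 log units; beyond the scatter) is of similar size. Every measured step concerns only the chain on the aromatic nitrogen; the cyclopentylamine on the shared core is kept throughout.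

Within the data shown here, compound 4 `CCCn1c(-c2ccccc2)nc2c(N)ncnc21` is the first compound to change that position: hydrogen in place of cyclopentyl on a nitrogen on an aromatic ring. Among the measured compounds shown here, no measured step bears on this change, so the three known steps give no direct size to expect. The change removes a whole saturated ring from the amine, a much larger change than any chain edit measured, and the expectation is a higher number in this assay, well beyond the scatter. The expected step is a 10-fold higher number from compound 1 to compound 4 (1.00 log units; beyond the scatter). Compound 4 is therefore estimated at 7500 nM, with a range from 2000 nM to 30000 nM.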

Compound 4, inhibition constant: 9280 nM
Compound 4: the middle estimate sits 1.2-fold (0.09 log units) below what was measured; low and high end bracket the measured number.
By their numbers in this assay, from the lowest: compound 3; then compounds 1 and 2 (each within the scatter of the next); then compound 4.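

Hydrogen in place of cyclopentyl on the nitrogen on the aromatic ring gives a 12-fold higher number from compound 1 to compound 4 (1.09 log units; beyond the scatter) in this assay and is the first large step in the series. It is clearly bigger than the chain steps on the aromatic nitrogen, such as a 2.4-fold lower number from compound 2 to compound 3 (0.38 log units; beyond the scatter) in the same assay, so with the chain of compound 1 held constant the cyclopentylamino group carries far more of the number than those chain edits do. No measurement available here explains the size of this step.

From the compounds shown here alone, it remains open whether the number depends on the cyclopentyl ring itself or on any saturated group at this nitrogen, which cyclopropyl, cyclohexyl or a simple methyl on the amine would test. Going by these compounds, it also remains open whether cyclopentylamino to amino gives a step of similar size on the methyl and ethyl chains of compound 2 and compound 3, or whether a longer chain such as butyl on the aromatic nitrogen changes it.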